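The source may hold more compounds than are shown below. What is called first, only, known or untested is meant among the compounds shown, and "the series" means these compounds.

Series notes. In a functional assay on CHO-K cells with growth hormone secretagogue receptor type 1 (Homo sapiens) as the target, read by FLIPR (on this read-out lower numbers stand for stronger inhibition and higher numbers for weaker inhibition), compound 1 `CCCc1onc(-c2c(Cl)cccc2Cl)c1C(=O)Nc1ccc(N(CC)CC)cc1` gives 492 nM, compound 2 `CCN(CC)c1ccc(NC(=O)c2c(-c3c(Cl)cccc3Cl)noc2CCOC)cc1` gives 115 nM, and compound 3 `CCN(CC)c1ccc(NC(=O)c2c(-c3c(Cl)cccc3Cl)noc2CCC2CCCO2)cc1` gives 57 nM; for compound 3 the step of a 2.0-fold lower number from compound 2 to compound 3 (0.30 log units; within the scatter) sits within the scatter, whereas an 8.6-fold lower number from compound 1 to compound 3 (0.94 log units; beyond the scatter) is beyond it. Compound 4 `CCN(CC)c1ccc(NC(=O)c2c(-c3c(Cl)cccc3Cl)noc2CN2CCCC2=O)cc1` carries 2-oxopyrrolidin-1-yl in place of (oxolan-2-yl)methyl on a saturated chain carbon bound to an aromatic carbon, which read one bond further out is 2-(oxolan-2-yl)ethyl to (2-oxopyrrolidin-1-yl)methyl. For the measured compounds named here, no measured step swaps one ring-bearing chain for another; the steps that bear on it are a 4.3-fold lower number from compound 1 to compound 2 (0.63 log units; beyond the scatter) and an 8.6-fold lower number from compound 1 to compound 3 (0.94 log units; beyond the scatter), both toward lower numbers when the chain terminus changes, and the small 2.0-fold lower number from compound 2 to compound 3 (0.30 log units; within the scatter). A step in this assay of about a 1.8-fold higher number from compound 3 to compound 4 (0.24 log units; within the scatter) is therefore expected for compound 4, not clearly beyond the scatter. Compound 4 is estimated at 100 nM, range 30 nM to 350 nM.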

Compound 4, half-maximal inhibitory concentration: 98 nM
The estimate for compound 4 lay 1.0-fold (0.01 log units) above the measured number, within the range that was stated.
By their numbers in this assay, from the lowest: compounds 3, 4 and 2 (each within the scatter of the next); then compound 1.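

On the saturated chain carbon bound to an aromatic carbon, 2-oxopyrrolidin-1-yl brings in a ring nitrogen and a double bond outside aromatic rings without a step beyond the scatter: a 1.7-fold higher number from compound 3 to compound 4 (0.24 log units; within the scatter) and a 1.2-fold lower number from compound 2 to compound 4 (0.07 log units; within the scatter), so compounds 2, 3 and 4 cannot be ordered. The separation from the simple alkyl chain of compound 1 holds for this group as well, with a 5.0-fold lower number from compound 1 to compound 4 (0.70 log units; beyond the scatter). No data here account for these steps. Open, going by these compounds, is whether the ring carbonyl matters, which pyrrolidin-1-yl would test, and whether a carboxylic acid at this carbon would give a step beyond the scatter from compound 4.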